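Nitro in place of hydroxy on the compound 1 core

The compounds below may be only part of what the source reports. "The series", "measured", "known", "first", "only" and "open" are said of these compounds alone.

Working notes on the series, followed in an ADME assay on MT4 cells (Homo sapiens) for cytotoxicity, read by MTT assay, with a stated time of 96 h; a higher number here means that more compound is tolerated, a lower number that less compound is tolerated. Compound 1 `Oc1ccc(-c2nc3cc(C(F)(F)F)ccc3[nH]2)cc1` gives 17000 nM. Compound 3 `Nc1ccc(-c2nc3cc(Cl)c(Cl)cc3[nH]2)cc1` gives 17000 nM, the same number as compound 1 at the digits shown, and together these two are the lowest of the three values. Compound 2 `O=C(CN1CCCC1)Nc1ccc(-c2nc3ccccc3[nH]2)cc1` gives 40000 nM, a higher number than compound 1 and beyond the scatter. Compound 4 `O=[N+]([O-])c1ccc(-c2nc3cc(C(F)(F)F)ccc3[nH]2)cc1` is not yet measured; it differs from compound 1 as follows: nitro in place of hydroxy on an aromatic carbon. Among the compounds with values here, no measured pair in the set shows a nitro in place of hydroxy, so the size of that step cannot be read from data. A step no larger than the scatter is expected, a 1.1-fold lower number from compound 1 to compound 4 (0.05 log units; within the scatter), with no clear direction. Compound 4 is estimated at 15000 nM, with a range from 6000 nM to 45000 nM.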

Compound 4, half-maximal cytotoxic concentration: 6000 nM
Estimate against measurement, compound 4: 2.5-fold (0.40 log units) above; the measured number falls inside the stated range.
By their numbers in this assay, from the lowest: compound 4; then compounds 1 and 3 (each within the scatter of the next); then compound 2.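

On the core of compound 1, the position para to a large group is not indifferent to substitution in this assay: nitro in place of hydroxy gives a step beyond the scatter (a 2.8-fold lower number from compound 1 to compound 4 (0.45 log units; beyond the scatter)). This exchange also removes the hydrogen-bond donor of hydroxy, so the step reflects a change of group rather than an isolated feature. No measured property bears on the origin of this step.

As far as these compounds go, whether the lower number follows the loss of that donor or the presence of nitro stays open. A methoxy group or a nitrile on the same carbon would help separate the two.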